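One Group Swapped on a Ring Nitrogen

A few compounds are considered here, and "the series" means these few. Any claim that something is new, unique, unknown or untested is made for them only; others in the source may bear on it.

In a functional assay on A549 cells (Homo sapiens) for antiproliferative activity, read by MTT assay, with a stated time of 72 h (a higher number here means a weaker inhibitor, a lower number a stronger inhibitor), compound 3 `COc1cccc(N2C(=O)COc3ccc(-c4cnc(OC)c(NS(=O)(=O)c5ccc(F)cc5)c4)cc32)c1` gives 11200 nM. This cannot be told apart from compound 2 `COc1ncc(-c2ccc3c(c2)NC(=O)CO3)cc1NS(=O)(=O)c1ccc(F)cc1` at 8070 nM or compound 1 `COc1ncc(-c2ccc3c(c2)N(c2ccc(C)cc2)C(=O)CO3)cc1NS(=O)(=O)c1ccc(F)cc1` at 5870 nM, since all three lie within the usual scatter of one another. Compound 4 `COc1ncc(-c2ccc3c(c2)N(c2ccc(F)cc2)C(=O)CO3)cc1NS(=O)(=O)c1ccc(F)cc1` differs from compound 3 in a single group: 4-fluorophenyl in place of 3-methoxyphenyl on an amide-type nitrogen in a ring. In words, 4-fluorophenyl stands in place of 3-methoxyphenyl on an amide-type nitrogen in a ring. Three measured steps change this same place: a 1.4-fold higher number from compound 1 to compound 2 (0.14 log units; within the scatter), a 1.4-fold higher number from compound 2 to compound 3 (0.14 log units; within the scatter) and a 1.9-fold higher number from compound 1 to compound 3 (0.28 log units; within the scatter). Each stays within the scatter, even where hydrogen replaces the whole group. Among the measured compounds shown here, no measured compound carries 4-fluorophenyl here, so this is an extrapolation, and no step beyond the scatter is expected in this assay. The estimate leans slightly towards compound 1, with its 4-methylphenyl group and 5870 nM. The estimated change is a 1.5-fold lower number from compound 3 to compound 4 (0.17 log units; within the scatter), which is no real shift. For compound 4 the expected value is 7500 nM, with an estimated range of 3800 nM to 14500 nM.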

Compound 4, half-maximal inhibitory concentration: 6500 nM
Compound 4: the middle estimate sits 1.2-fold (0.06 log units) above what was measured; the measured number falls inside the stated range.
By their numbers in this assay, from the lowest: compounds 1, 4, 2 and 3 (each within the scatter of the next).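

In this assay the new 4-fluorophenyl group stays within the scatter of all three groups already measured on this nitrogen (a 1.7-fold lower number from compound 3 to compound 4 (0.24 log units; within the scatter)) (a 1.2-fold lower number from compound 2 to compound 4 (0.09 log units; within the scatter)) (a 1.1-fold higher number from compound 1 to compound 4 (0.04 log units; within the scatter)). The last step is the closest comparison so far, since only fluoro in place of methyl on an aromatic carbon separates the two compounds, and even the swap from 3-methoxyphenyl to 4-fluorophenyl gives no real shift. Across hydrogen and three substituted phenyl groups, this position has therefore shown no step beyond the scatter, and no measured evidence offers an explanation for that.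

On these data alone, it remains open whether a group of a different kind on this nitrogen, such as a chain ending in an amine or a carboxylic acid, would move the number. Changes elsewhere on the shared core also remain open.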